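A few compounds are considered here, and "the series" means these few. Any claim that something is new, unique, unknown or untested is made for them only; others in the source may bear on it.

Measured so far in an ADME assay on microsomes from liver (Rattus norvegicus, strain Wistar) for metabolic stability, tested at 2.5 uM; on this read-out higher numbers stand for fast clearance and lower numbers for slow clearance:
- compound 1, `Fc1cc(Cl)ccc1-c1ccc(Cn2nnc3ccccc32)cn1`: 0.8 mL/min/g
- compound 2, `Fc1ccc2nnn(Cc3ccc(-c4ccc(Cl)cc4F)nc3)c2c1`: 1 mL/min/g
- compound 3, `Brc1cccc2c1nnn2Cc1ccccc1`: 2 mL/min/g

Compounds 1 and 2 share a core and differ by one change, (fluoro in place of hydrogen on an aromatic carbon). That change gave a 1.3-fold higher number from compound 1 to compound 2 (0.10 log units; within the scatter). Among the compounds with values here, compound 3 carries a different core; how the two cores differ is not broken down here, and what can be said is only that compound 1 gives 0.8 mL/min/g while compound 3 gives 2 mL/min/g, a gap that lies beyond the scatter, whereas compound 2 and compound 3 sit within the scatter of each other.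

Compound 4, `Fc1ccc(Cn2nnc3c(Br)cccc32)cc1`, is not yet measured. It differs from compound 3 by fluoro in place of hydrogen on an aromatic carbon. This is the same kind of change as that from compound 1 to compound 2, though the surroundings differ: in compound 2 the fluoro sits on a ring that is part of a fused or bridged system of two rings, meta to a fused ring and para to a fused ring, while in compound 4 it sits on a ring of carbon only, para to a large group. Because the earlier change gave a 1.3-fold higher number from compound 1 to compound 2 (0.10 log units; within the scatter), the step from compound 3 to compound 4 is expected to be small, a 1.2-fold higher number from compound 3 to compound 4 (0.08 log units; within the scatter), in this assay. Compound 4 is thus estimated at 2.4 mL/min/g, with a likely range from 1.2 mL/min/g to 5 mL/min/g.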

Compound 4, intrinsic clearance in a liver preparation (reported as CLH), per the amount of preparation that the assay uses: 1 mL/min/g
Beside the measured number, compound 4's estimate is 2.4-fold (0.38 log units) above it; the measured number lies below the stated range.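

In this assay, fluoro in place of hydrogen on an aromatic carbon gave a 2.0-fold lower number from compound 3 to compound 4 (0.30 log units; within the scatter). Set beside the earlier step, the change does not differ between the two cores by more than the usual scatter: the same change on two cores in this assay, a 1.3-fold higher number (0.10 log units; within the scatter) from compound 1 to compound 2 and a 2.0-fold lower number (0.30 log units; within the scatter) from compound 3 to compound 4, 2.5-fold (0.40 log units) apart, within the scatter of two such steps. Within the data shown here, this shows that the change moved the number beyond the scatter on neither core and that the opposite directions of the two steps cannot be read as a real difference, but it does not show that the change would act alike on other cores, as there are only two pairs and the fluoro sits in a different setting in each.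

The compounds shown leave open whether a methoxy group or an amine, on the same ring of carbon only and para to a large group, would shift the number beyond the scatter. They also leave open how the number would respond on the core of compound 3 to a nitrile or a carboxylic acid in place of the bromo.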